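Meta-substituent variation on the aryl urea of the shared core

The compounds below may be only part of what the source reports. "The series", "measured", "known", "first", "only" and "open" are said of these compounds alone.

Measured compounds:
- compound 1, `Cc1cccc(NC(=O)Nc2nnc(Sc3ncnc4scc(-c5ccncc5)c34)s2)c1`: 27200 nM
- compound 2, `O=C(Nc1cccc(Cl)c1)Nc1nnc(Sc2ncnc3scc(-c4ccncc4)c23)s1`: 43900 nM

Both compounds were run in a functional assay on T47D cells (Homo sapiens) for antiproliferative activity, read by MTT assay, with a stated time of 48 h; on this read-out higher numbers stand for weaker inhibition and lower numbers for stronger inhibition. Going by the values given here, the only step so far, a 1.6-fold higher number from compound 1 to compound 2 (0.21 log units; within the scatter), shows that compound 2 and compound 1 sit within the scatter of each other; nothing separates them on this read-out, and compound 2 has no other neighbour to compare with.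

Compound 3, `O=C(Nc1cccc(C(F)(F)F)c1)Nc1nnc(Sc2ncnc3scc(-c4ccncc4)c23)s1`, is the next member. Its difference from compound 2 is trifluoromethyl in place of chloro on an aromatic carbon. Among the compounds with values here, the one step that bears on this position, a 1.6-fold higher number from compound 1 to compound 2 (0.21 log units; within the scatter), stayed within the scatter, so a change of this kind at this place has so far moved nothing. No step beyond the scatter in this assay is therefore expected for compound 3, with the estimate set slightly to the weaker side only because of the direction of a 1.6-fold higher number from compound 1 to compound 2 (0.21 log units; within the scatter). The step from compound 2 to compound 3 is expected to be a 1.1-fold higher number from compound 2 to compound 3 (0.06 log units; within the scatter). For compound 3 the estimate is 50000 nM, with a range from 20000 nM to 120000 nM.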

Compound 3, half-maximal inhibitory concentration: 45100 nM
The estimate for compound 3 lay 1.1-fold (0.04 log units) above the measured number, within the range that was stated.
By their numbers in this assay, from the lowest: compounds 1, 2 and 3 (each within the scatter of the next).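

In this assay trifluoromethyl joins methyl and chloro at this place on the aromatic ring, and both new steps stay within the scatter (a 1.0-fold higher number from compound 2 to compound 3 (0.01 log units; within the scatter)) (a 1.7-fold higher number from compound 1 to compound 3 (0.22 log units; within the scatter)). The earlier compounds shown here offered one comparison, whereas three groups now cannot be told apart on this read-out, even though the change from chloro, with 1 heavy atom, to trifluoromethyl, with 4 heavy atoms, enlarges the substituent. No supporting data accompany these numbers to account for this flat result.

Open, as far as these compounds go, is whether an amine, a carboxylic acid or a longer alkyl chain at this place would give a step beyond the scatter. Also open, from the compounds shown here alone, is whether the same three groups would behave alike at another carbon of the same aromatic ring.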